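Trimming the Amide Aryl Tail in a Growth-Inhibition Series

The source may report more compounds than this note shows. Statements on the series, on what has been measured and on what is new or still open speak of the compounds shown alone.

Compound 1 `COc1cc(-c2nn(-c3cccc(NC(=O)Nc4ccc(Cl)c(Cl)c4)c3)cc2-c2ccncc2)ccc1Cl` gives 1440 nM in a functional assay on HOP-62 cells (Homo sapiens) for inhibition, read by sulforhodamine B assay, with a stated time of 48 h; a higher number here means a weaker inhibitor of growth, a lower number a stronger inhibitor of growth.
Compound 2 `O=C(Nc1cccc(-n2cc(-c3ccncc3)c(-c3ccc(Cl)c(O)c3)n2)c1)Nc1ccc(Cl)c(Cl)c1` gives 2080 nM.
Compound 3 `COc1cc(-c2nn(-c3cccc(NC(=O)c4ccc(Cl)c(C(F)(F)F)c4)c3)cc2-c2ccncc2)ccc1Cl` gives 13100 nM.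

Compound 3 carries the highest number of the three, so it is the weakest inhibitor of growth so far; its gaps to compound 2 and to compound 1 both lie beyond the scatter. Compound 4 `COc1cc(-c2nn(-c3cccc(NC(=O)c4ccccc4)c3)cc2-c2ccncc2)ccc1Cl` changes only the amide tail: phenyl in place of 4-chloro-3-(trifluoromethyl)phenyl on a carbonyl carbon. For the measured compounds named here, no measured pair swaps one ring for another on this carbonyl carbon. Going by the values given here, the only step touching this end, a 9.1-fold higher number from compound 1 to compound 3 (0.96 log units; beyond the scatter), replaced a urea with an amide and raised the number; it does not separate ring from linker. Compound 4 is therefore expected near 25000 nM, between 7000 nM and 90000 nM. The expected step is a 1.9-fold higher number from compound 3 to compound 4 (0.28 log units; within the scatter), a further, uncertain weakening.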

Compound 4, concentration for 50% growth inhibition: 8340 nM
Compound 4: middle estimate off by 3.0-fold (0.48 log units), on the high side, and the stated range covers the measured number.
By their numbers in this assay, from the lowest: compounds 1 and 2 (each within the scatter of the next); then compounds 4 and 3 (each within the scatter of the next).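

In this assay, replacing the substituted ring with plain phenyl gives a 1.6-fold lower number from compound 3 to compound 4 (0.20 log units; within the scatter) and so, on this carbonyl carbon, the chloro and trifluoromethyl groups together make no difference that can be told from the scatter. The gap to the urea remains, with a 5.8-fold higher number from compound 1 to compound 4 (0.76 log units; beyond the scatter) and this step changes both the linker and the ring, so it cannot be assigned to either alone. Nothing measured here gives a reason for either step.

On these data alone, it remains open whether a urea ending in plain phenyl would match compound 1, and whether an amine or a carboxylic acid on the amide's phenyl ring would shift the number.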